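The compounds below may be only part of what the source reports. "The series", "measured", "known", "first", "only" and "open" are said of these compounds alone.

Values in a functional assay on DU-145 cells (Homo sapiens) for cytotoxicity, read by MTT assay, with a stated time of 72 h; on this read-out higher numbers stand for weaker inhibition and lower numbers for stronger inhibition:

compound 1 `COc1cccc(/C=C/C(=O)Nc2cc(C(=O)c3cc(OC)c(OC)c(OC)c3)ccc2OC)c1`: 6200 nM
compound 2 `C#CCOc1cccc(/C=C/C(=O)Nc2cc(C(=O)c3cc(OC)c(OC)c(OC)c3)ccc2OC)c1`: 15800 nM
compound 3 `COc1ccc(C(=O)c2cc(OC)c(OC)c(OC)c2)cc1NC(=O)/C=C/c1ccc(C(F)(F)F)cc1`: 4300 nM

Compound 3 holds the lowest of the three numbers in this assay; its nearest neighbour is compound 1, a 1.4-fold lower number from compound 1 to compound 3 (0.16 log units; within the scatter), and its furthest is compound 2, a 3.7-fold lower number from compound 2 to compound 3 (0.57 log units; beyond the scatter). Compound 4 `COc1ccc(C(=O)c2cc(OC)c(OC)c(OC)c2)cc1NC(=O)/C=C/c1cccc(OC(F)(F)F)c1` differs from compound 3 in one place: 3-(trifluoromethoxy)phenyl in place of 4-(trifluoromethyl)phenyl on a double-bonded chain carbon bound to a double-bonded chain carbon. Within the data shown here, the steps that bear on this are the two earlier swaps of the aryl group on that same carbon, a 1.4-fold lower number from compound 1 to compound 3 (0.16 log units; within the scatter) and a 3.7-fold lower number from compound 2 to compound 3 (0.57 log units; beyond the scatter), one within the scatter and one modest. A further aryl swap of this kind is therefore expected to move the number little, if at all beyond the scatter, giving a 1.2-fold higher number from compound 3 to compound 4 (0.07 log units; within the scatter). Compound 4 is estimated at 5000 nM, with a range from 2500 nM to 10000 nM.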

Compound 4, half-maximal inhibitory concentration: 10200 nM
Beside the measured number, compound 4's estimate is 2.0-fold (0.31 log units) below it; measured number above the stated range.
By their numbers in this assay, from the lowest: compounds 3, 1, 4 and 2 (each within the scatter of the next, the first and the last beyond it).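

In this assay, the swap on this double-bonded chain carbon now gives a step beyond the scatter (a 2.4-fold higher number from compound 3 to compound 4 (0.38 log units; beyond the scatter)), so the 4-(trifluoromethyl)phenyl of compound 3 stands apart from 3-(trifluoromethoxy)phenyl as well as from 3-(propargyloxy)phenyl. On the aryl oxygen, trifluoromethyl reads within the scatter of both methyl (a 1.6-fold higher number from compound 1 to compound 4 (0.22 log units; within the scatter)) and propargyl (a 1.5-fold lower number from compound 2 to compound 4 (0.19 log units; within the scatter)), although those two groups differ beyond it. Nothing measured here gives a cause for these steps. The step from compound 3 to compound 4 changes both the group and its place on the ring, and the compounds shown do not separate the two. Going by these compounds, how an amine or a carboxylic acid on this aryl group would read also remains open.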